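Swapping an Aromatic Ring for a Saturated One

A few compounds are considered here, and "the series" means these few. Any claim that something is new, unique, unknown or untested is made for them only; others in the source may bear on it.

The three compounds share one core and differ only in the group carried on an amide-type nitrogen. Compound 1, `COc1cc(-c2cc(C(=O)O)c3ccccc3n2)ccc1OCC(=O)Nc1ccc(C)cc1`, was tested in an ADME assay on HaCaT cells (Homo sapiens) for inhibition; a higher number here means a weaker inhibitor, a lower number a stronger inhibitor. In that assay compound 1 gives > 300000 nM, which is a limit of the assay; this is the limit of > 300000 nM in this assay, at which 1 of the 2 values shown sits. Compound 2, `COc1cc(-c2cc(C(=O)O)c3ccccc3n2)ccc1OCC(=O)Nc1ccccc1F`, carries a 2-fluorophenyl on the same nitrogen, and in this assay compound 2 gives 161000 nM. For the measured compounds named here, the step of an at least 1.8-fold lower number from compound 1 to compound 2 (0.27 log units; that floor lies within the scatter) is the only measured change available, and its floor lies within the usual scatter, so it shows little more than that both compounds are very weak inhibitors.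

Compound 3, `COc1cc(-c2cc(C(=O)O)c3ccccc3n2)ccc1OCC(=O)NC1CCCCC1`, has not yet been measured. Its change from compound 1 is cyclohexyl in place of 4-methylphenyl on an amide-type nitrogen. Going by the values given here, no measured step here replaces an aromatic ring with a saturated one, so the step from compound 1 to compound 2 bears on it only loosely. Compound 1 sits at a limit, and a weak inhibitor is the likely outcome once more. Compound 3 is therefore expected to show a step of a number no higher from compound 1 to compound 3 (the limit leaves the size open), not beyond the scatter. The estimate for compound 3 in this assay is 300000 nM, within 120000 nM to 700000 nM.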

Compound 3, half-maximal inhibitory concentration: > 300000 nM
Compound 3: a limit, no number; the forecaster's own chance of this, stated with the estimate: 50%; the middle value sits exactly at the limit.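

In this assay compound 3 gives > 300000 nM, which is a limit of the assay and not a number. This is the only swap of an aromatic ring for a non-aromatic one shown here, and it did not bring the compound into the range where the assay gives a number, so the step between the 4-methylphenyl and cyclohexyl compounds cannot be read and the two rings cannot be ranked at this position: the limit of > 300000 nM in this assay, at which 2 of the 3 values shown sit. Set against the other aromatic group, the change gives an at least 1.8-fold higher number from compound 2 to compound 3 (0.27 log units; that floor lies within the scatter), so cyclohexyl on the amide-type nitrogen is not shown to differ from 2-fluorophenyl, and all that can be said is that no compound here is more than a very weak inhibitor.

The compounds shown leave open whether a smaller saturated ring such as cyclopentyl, or a chain ending in an amine or a carboxylic acid, on the same nitrogen would give a clearly lower number in this assay. They also leave open which of the two rings, 4-methylphenyl or cyclohexyl, gives the weaker inhibitor, a question that only a readable number for each could settle.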